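The source may report more compounds than this note shows. Statements on the series, on what has been measured and on what is new or still open speak of the compounds shown alone.

Compound 2 `CCc1nn(C)c(CO/N=C/c2c(C)nn(C)c2Oc2ccccc2Cl)c1Cl` carries a 2-chlorophenyl on an oxygen of the shared core. In a functional assay on SMMC-7721 cells (Homo sapiens) for inhibition, read by MTT assay, with a stated time of 72 h, tested at 25 uM (a higher number here means more inhibition at the concentration tested (going by the name of the read-out), a lower number less inhibition), compound 2 gives only a limit, < 80%. Its neighbour compound 1 `CCc1nn(C)c(CO/N=C/c2c(C)nn(C)c2Oc2ccc(F)cc2)c1Cl` likewise gives only a limit in this assay, < 80%. The step that the two limits leave unreadable from compound 1 to compound 2 thus cannot be read, since both values sit at the limit of < 80% in this assay, at which 2 of the 2 values shown sit. Compound 3 `CCc1nn(C)c(CO/N=C/c2c(C)nn(C)c2Oc2ccc(Br)cc2)c1Cl` differs from compound 2 by 4-bromophenyl in place of 2-chlorophenyl on an oxygen on an aromatic ring. Among the compounds with values here, no measured step bears on this change, so compound 3 is expected to show a step that the limit leaves unreadable from compound 2 to compound 3, probably nothing beyond the scatter. Compound 3 is estimated at 40%, between 5% and 79%.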

Compound 3, a percentage reported as inhibition, at one concentration (the size of the read-out at that concentration, not a potency): < 80%
Compound 3: a limit, no number; the forecaster's own chance of this, stated with the estimate: 80%; the middle value lies beyond the limit too.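

No step to compound 3 from compound 1 or compound 2 can be read in this assay, because all three values are limits: the limit of < 80% in this assay, at which 3 of the 3 values shown sit.

The compounds shown leave open whether swapping the substituted phenyl on the oxygen changes inhibition at all.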